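Bromo for chloro in a small antiproliferative series

A few compounds are considered here, and "the series" means these few. Any claim that something is new, unique, unknown or untested is made for them only; others in the source may bear on it.

Measured compounds:
compound 1 `O=C(Nc1ccccc1Cl)C(Cl)Cl` 50200 nM
compound 2 `O=C(Nc1ccccc1Br)C(Cl)Cl` 37000 nM
compound 3 `O=C(Nc1ccc(Cl)cc1)C(Cl)Cl` 20400 nM

All three were run in a functional assay on A549 cells (Homo sapiens) for antiproliferative activity, read by MTT assay, with a stated time of 72 h; a higher number here means a weaker inhibitor, a lower number a stronger inhibitor. Compound 3 gives the lowest number, though its gap to compound 2 lies within the scatter. The difference between the core of compound 1 and the core of compound 3 is not broken down here.

Compound 2 differs from compound 1 by bromo in place of chloro on an aromatic carbon and this gave a 1.4-fold lower number from compound 1 to compound 2 (0.13 log units; within the scatter). Compound 4 `O=C(Nc1ccc(Br)cc1)C(Cl)Cl` differs from compound 3 by bromo in place of chloro on an aromatic carbon. The two changes are the same kind of change, not the same: in compound 2 the bromo sits ortho to a group of 6 heavy atoms, in compound 4 para to a group of 6 heavy atoms. For compound 4 a step of about the earlier size is expected, a 1.4-fold lower number from compound 3 to compound 4 (0.13 log units; within the scatter), because compound 2 gave a 1.4-fold lower number from compound 1 to compound 2 (0.13 log units; within the scatter). Compound 4 is estimated at 15000 nM, between 7000 nM and 35000 nM.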

Compound 4, half-maximal inhibitory concentration: 13700 nM
The estimate for compound 4 lay 1.1-fold (0.04 log units) above the measured number; the measured number falls inside the stated range.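

Bromo in place of chloro gives a 1.5-fold lower number from compound 3 to compound 4 (0.17 log units; within the scatter) in this assay. Set beside the earlier step, the change carries from one core to the other with no difference that can be told apart: the same change on two cores in this assay, a 1.4-fold lower number (0.13 log units; within the scatter) from compound 1 to compound 2 and a 1.5-fold lower number (0.17 log units; within the scatter) from compound 3 to compound 4, 1.1-fold (0.04 log units) apart, within the scatter of two such steps. Each step lies within the scatter on its own, so the two cores agree only in showing no clear effect of the swap; this does not show that bromo improves on chloro, and it covers only these two cores.

Still open, as far as these compounds go, is whether an amine, a methoxy group or a carboxylic acid in place of the halogen would give a step clear of the scatter. Also open, from the compounds shown here alone, is whether a longer chain in place of the dichloromethyl end of the amide would change the picture.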